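This account rests on a few compounds, and the source may have more. Where it says the series, first, only, none or still open, it means among the compounds named here.

Measured in a functional assay (aorta) with Rattus norvegicus as the target; on this read-out lower numbers stand for stronger inhibition and higher numbers for weaker inhibition:
- compound 1 `CC(C)c1cn2ccccc2c1S(=O)(=O)c1ccc(OCCCNCc2ccccc2)cc1`: 22.8 nM
- compound 2 `CC(C)c1cn2ccccc2c1S(=O)(=O)c1ccc(OCCCN2CCC(c3ccccc3)CC2)cc1`: 80.9 nM
- compound 3 `CCN(CC)CCCOc1ccc(S(=O)(=O)c2c(C(C)C)cn3ccccc23)cc1`: 228 nM

Compound 3 has the highest number of the three, which makes it the weakest inhibitor in this small set. The next compound, compound 4 `CC(C)c1cn2ccccc2c1S(=O)(=O)c1ccc(OCCCNC(C)(C)C)cc1`, keeps the shared core and the chain but rearranges the amine: (tert-butyl)amino in place of diethylamino on a saturated chain carbon, three bonds along the chain from an oxygen on an aromatic ring. For the measured compounds named here, no measured step makes this exact change, so the evidence is indirect. Swapping benzylamino for diethylamino gave a 10-fold higher number from compound 1 to compound 3 (1.00 log units; beyond the scatter). Swapping 4-phenylpiperidin-1-yl for diethylamino gave a 2.8-fold higher number from compound 2 to compound 3 (0.45 log units; beyond the scatter). Of the measured compounds, only compound 1 carries a hydrogen-bond donor in this group, as (tert-butyl)amino does. However, (tert-butyl)amino has no ring, and compound 1 is a single example. A partial return towards compound 1 therefore seems reasonable, in the direction of a lower number in this assay. The expected change is a 2.5-fold lower number from compound 3 to compound 4 (0.40 log units; beyond the scatter), a moderate step with real uncertainty. For compound 4 the estimated value is 90 nM, with an expected range of 25 nM to 300 nM.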

Compound 4, half-maximal inhibitory concentration: 41.8 nM
Beside the measured number, compound 4's estimate is 2.2-fold (0.33 log units) above it; the measured number falls inside the stated range.
By their numbers in this assay, from the lowest: compounds 1, 4 and 2 (each within the scatter of the next, the first and the last beyond it); then compound 3.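

Diethylamino and (tert-butyl)amino have the same atoms, joined differently, yet the swap leaves a clear mark in this assay (a 5.5-fold lower number from compound 3 to compound 4 (0.74 log units; beyond the scatter)), so at this position how the atoms are joined counts, not only which atoms are present. A ring in this group is also not needed to reach the better range: (tert-butyl)amino has none, yet its gaps to the two amines that do carry a ring (a 1.9-fold lower number from compound 2 to compound 4 (0.29 log units; within the scatter) and a 1.8-fold higher number from compound 1 to compound 4 (0.26 log units; within the scatter)) both lie within the scatter.

From the compounds shown here alone, how a plain piperidin-1-yl, a cyclopropylamino group or a longer chain between the oxygen and the amine would read here remains open. Nothing measured here offers a reason for the size of these steps.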